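From 3-methoxyphenyl to 2-methoxyphenyl in compound 4

The compounds below may be only part of what the source reports. "The series", "measured", "known", "first", "only" and "open" are said of these compounds alone.

Three related compounds have been measured so far in a functional assay on THP-1 cells (Homo sapiens) for cytotoxicity, read by sulforhodamine B assay, with a stated time of 48 h; on this read-out higher numbers stand for weaker inhibition and lower numbers for stronger inhibition. Compound 1 (`COc1cc(/C=C/C(=O)/C=C/c2cccc3ccccc23)ccc1OCc1cn(CCCOc2cc(=O)oc3ccccc23)nn1`) gives 8410 nM, compound 2 (`COc1cccc(/C=C/C(=O)/C=C/c2ccc(OCc3cn(CCOc4cc(=O)oc5ccccc45)nn3)c(OC)c2)c1`) gives 7130 nM and compound 3 (`COc1cc(/C=C/C(=O)/C=C/c2cc(OC)c(OC)c(OC)c2)ccc1OCc1cn(CCCOc2cc(=O)oc3ccccc23)nn1`) gives 5430 nM. Repeated measurements of this kind always vary somewhat, and these three numbers all lie within that usual scatter of one another. Compound 2 therefore stands level with the other two, not apart from them.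

Compound 4 (`COc1ccccc1/C=C/C(=O)/C=C/c1ccc(OCc2cn(CCOc3cc(=O)oc4ccccc34)nn2)c(OC)c1`) has the same atoms as compound 2, joined differently: 2-methoxyphenyl in place of 3-methoxyphenyl on a double-bonded chain carbon bound to a double-bonded chain carbon. In words, 2-methoxyphenyl sits in place of 3-methoxyphenyl on a double-bonded chain carbon bound to a double-bonded chain carbon.

Among the measured compounds shown here, no measured pair compares these two groups directly. For the measured compounds named here, the one measured step that bears on this place is a 1.5-fold lower number from compound 1 to compound 3 (0.19 log units; within the scatter). It exchanges naphthalen-1-yl for 3,4,5-trimethoxyphenyl at the same kind of position, a far larger change in the group than the one here, and it still stays within the scatter. On that evidence, no step beyond the scatter is expected, and no direction can be favoured. The expected change is a 1.1-fold lower number from compound 2 to compound 4 (0.04 log units; within the scatter), which is an estimate and no larger than the scatter. For compound 4 the estimated value is 6500 nM, with an expected range from 3200 nM to 13000 nM.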

Compound 4, half-maximal inhibitory concentration: 7330 nM
Compound 4: middle estimate off by 1.1-fold (0.05 log units), on the low side; low and high end bracket the measured number.
By their numbers in this assay, from the lowest: compounds 3, 2, 4 and 1 (each within the scatter of the next).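

In this assay, putting 2-methoxyphenyl in place of 3-methoxyphenyl on a double-bonded chain carbon bound to a double-bonded chain carbon gives a 1.0-fold higher number from compound 2 to compound 4 (0.01 log units; within the scatter) and leaves the two compounds level. Among the compounds shown here, this is the first direct comparison at this place of two groups built from the same atoms, whereas the earlier step exchanged two very different groups, naphthalen-1-yl and 3,4,5-trimethoxyphenyl. For this one pair, then, the different attachment of the methoxy group on the phenyl ring does not separate the two numbers, and no measurement at hand offers an explanation for that result.

All the groups shown at this place are naphthalen-1-yl or phenyl rings carrying methoxy groups, so it remains open whether a different kind of group, such as 4-aminophenyl or 4-carboxyphenyl, would give a step beyond the scatter. Going by these compounds, it also remains open whether 2-methoxyphenyl and 3-methoxyphenyl would stand level on the core of compound 1, whose chain to the triazole differs from that of compound 2.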